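The source may hold more compounds than are shown below. What is called first, only, known or untested is meant among the compounds shown, and "the series" means these compounds.

Working notes on the series. Compound 1 `Cn1ccc2c(Oc3ccc(NC(=O)c4nn(-c5ccc(Cl)cc5)ccc4=O)cc3F)ccnc21` and compound 2 `Cn1ccc2c(Oc3ccc(NC(=O)c4nn(-c5ccccc5)ccc4=O)cc3F)ccnc21` share one core and differ only in the aromatic substituent. In a functional assay on PC-3 cells (Homo sapiens) for cytotoxicity, read by MTT assay, with a stated time of 72 h (on this read-out lower numbers stand for stronger inhibition and higher numbers for weaker inhibition), compound 1 gives only a limit, > 60000 nM. In this assay compound 2 likewise gives only a limit, > 60000 nM. The step that the two limits leave unreadable from compound 1 to compound 2 is therefore unreadable, and the whole evidence on measured steps is confined to the limit of > 60000 nM in this assay, at which 2 of the 2 values shown sit. Compound 2 thus stands at the limit, with no number that would place it against compound 1.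

Compound 3 `Cn1ccc2c(Oc3ccc(NC(=O)c4nn(-c5ccc(Br)cc5F)ccc4=O)cc3F)ccnc21` is the next member, reached by 4-bromo-2-fluorophenyl in place of phenyl on an aromatic nitrogen. Within the data shown here, no measured step with a readable size bears on this change; the one step on the same aromatic substituent gave no size. The expected step that the limit leaves unreadable from compound 2 to compound 3 is therefore assumed to remain within the scatter and most likely to leave only a limit again. Compound 3 is estimated in this assay at 90000 nM, within 30000 nM to 300000 nM.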

Compound 3, half-maximal inhibitory concentration: 16300 nM
For compound 3 the middle estimate is 5.5-fold (0.74 log units) above the measured one, outside the stated range (below it).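

In this assay, the change to 4-bromo-2-fluorophenyl on the aromatic nitrogen brings an at least 3.6-fold lower number from compound 2 to compound 3 (0.56 log units; beyond the scatter), and the same change made from 4-chlorophenyl brings an at least 3.6-fold lower number from compound 1 to compound 3 (0.56 log units; beyond the scatter). This substituent can therefore move the read-out off the limit, which the unreadable step between compound 1 and compound 2 could not show, and both sizes are only lower bounds. The other values remain limits, so the comparison rests on a single measured number: the limit of > 60000 nM in this assay, at which 2 of the 3 values shown sit.

The change to compound 3 brings in bromo and fluoro together, so the compounds shown do not tell how much of the step belongs to either one. From the compounds shown here alone, how a methoxy group or a dimethylamino group would read on this aromatic substituent also remains open.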